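Benzyl to cyclohexyl on the aryl ether of compound 2

The source may report more compounds than this note shows. Statements on the series, on what has been measured and on what is new or still open speak of the compounds shown alone.

Three thioureas were measured in an assay on membranes from brain for binding affinity to Lysophosphatidylserine lipase ABHD12 (Mus musculus), read by fluorescence, with a stated time of 20 min; on this read-out higher numbers stand for weaker inhibition and lower numbers for stronger inhibition. Compound 1 `FC(F)(F)Oc1ccccc1Oc1ccnc(N2CCC(NC(=S)Nc3cccnc3)CC2)c1Cl` gives 96 nM, compound 3 `FC(F)(F)c1cc(N2CCC(NC(=S)Nc3cccnc3)CC2)ncc1Cl` gives 1400 nM, and compound 2 `S=C(Nc1cccnc1)NC1CCN(c2cc(OCc3ccccc3)ccn2)CC1` gives 2800 nM. Compound 2 therefore carries the highest number of the three: its value lies within the scatter of compound 3, while its gap to compound 1 lies well beyond it. Compound 4 `S=C(Nc1cccnc1)NC1CCN(c2cc(OC3CCCCC3)ccn2)CC1` differs from compound 2 in one place: cyclohexyl in place of benzyl on an oxygen on an aromatic ring. Among the measured compounds shown here, no measured pair in this set shows the same exchange, so the step has no precedent here. The expected step from compound 2 to compound 4 is a 1.1-fold lower number from compound 2 to compound 4 (0.05 log units; within the scatter), that is, none beyond the scatter. Compound 4 is estimated at 2500 nM, with a range from 900 nM to 7000 nM in this assay.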

Compound 4, half-maximal inhibitory concentration: 3400 nM
Beside the measured number, compound 4's estimate is 1.4-fold (0.13 log units) below it, within the range that was stated.
By their numbers in this assay, from the lowest: compound 1; then compounds 3, 2 and 4 (each within the scatter of the next, the first and the last beyond it).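

In this assay, among the compounds shown here, replacing benzyl with cyclohexyl on an oxygen on an aromatic ring is the first single-place step at this position, and it reads a 1.2-fold higher number from compound 2 to compound 4 (0.08 log units; within the scatter) and so stays within the scatter. Here, an aromatic carbon ring and a non-aromatic carbon ring on this oxygen are therefore not told apart by this read-out. Nothing shown bears on the reason for this result. Still open, on these data alone, is whether an amine, a carboxylic acid or a longer chain on this oxygen would produce a step beyond the scatter.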